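Removing a Chloro Group: What the Growth Numbers Suggest

This account rests on a few compounds, and the source may have more. Where it says the series, first, only, none or still open, it means among the compounds named here.

Of the compounds shown here, three sharing one core have been tested in a functional assay on cells (Panel NCI-60 (60 carcinoma cell lines), Homo sapiens) for inhibition, read by sulforhodamine B assay, with a stated time of 48 h; a lower number here means a stronger inhibitor of growth, a higher number a weaker inhibitor of growth. Compound 1 `COc1ccc(-c2ccc(-c3ccc(C(=N)N)o3)o2)cc1` gives 5890 nM, compound 2 `N=C(N)c1ccc(-c2ccc(-c3ccc(Cl)cc3)o2)o1` gives 3720 nM, and compound 3 `COc1cc(OC)cc(-c2ccc(-c3ccc(C(=N)N)o3)o2)c1` gives 8120 nM. Compound 2 stands at the low end of these three numbers, with compound 1 within the scatter of it and compound 3 beyond it. For the measured compounds named here, the only measured step, a 1.6-fold lower number from compound 1 to compound 2 (0.20 log units; within the scatter), shows that exchanging one small group for another at this aromatic carbon barely moves the number. Compound 4 `N=C(N)c1ccc(-c2ccc(-c3ccccc3)o2)o1` is not yet measured; it differs from compound 2 in that (hydrogen in place of chloro on an aromatic carbon). Because a 1.6-fold lower number from compound 1 to compound 2 (0.20 log units; within the scatter) was so small, only a modest rise is expected, a 1.5-fold higher number from compound 2 to compound 4 (0.17 log units; within the scatter). Compound 4 is therefore estimated at 5500 nM, with a range from 2700 nM to 11000 nM.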

Compound 4, concentration for total growth inhibition: 6910 nM
Compound 4: the middle estimate sits 1.3-fold (0.10 log units) below what was measured; the range from low to high includes it.
By their numbers in this assay, from the lowest: compounds 2, 1, 4 and 3 (each within the scatter of the next, the first and the last beyond it).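

In this assay, for the compounds shown here, hydrogen at this place gives a reference point that the earlier compounds lacked: removing chloro brings a 1.9-fold higher number from compound 2 to compound 4 (0.27 log units; within the scatter) and removing methoxy brings a 1.2-fold higher number from compound 1 to compound 4 (0.07 log units; within the scatter) and so neither group stands apart from plain hydrogen here. This aromatic carbon has therefore tolerated all three without a step beyond the scatter. No measurement shown accounts for these small steps.

Going by these compounds, whether an amine or a carboxylic acid on this carbon would give a step beyond the scatter remains open. So does whether a longer chain here would do so.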